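Replacing 4-hydroxyphenyl with 2,6-dimethoxyphenyl on the shared core

This account rests on a few compounds, and the source may have more. Where it says the series, first, only, none or still open, it means among the compounds named here.

Measured in a functional assay on OVCAR-3 cells (Homo sapiens) for inhibition, read by sulforhodamine B assay, with a stated time of 48 h; on this read-out lower numbers stand for stronger inhibition of growth and higher numbers for weaker inhibition of growth:
Compound 1 `O=C(Cc1csc2nc(-c3ccc(Br)cc3)cn12)N/N=C/c1ccccc1`: 46800 nM
Compound 2 `O=C(Cc1csc2nc(-c3ccc(Br)cc3)cn12)N/N=C/c1ccc(O)cc1`: 49000 nM

Among the compounds with values here, compound 2 lies within the scatter of compound 1, the only other compound measured so far. The next compound, compound 3 `COc1cccc(OC)c1/C=N/NC(=O)Cc1csc2nc(-c3ccc(Br)cc3)cn12`, differs from compound 2 by one change: 2,6-dimethoxyphenyl in place of 4-hydroxyphenyl on a carbon with a double bond to nitrogen. Within the data shown here, only one measured step bears on it: a 1.0-fold higher number from compound 1 to compound 2 (0.02 log units; within the scatter), with hydroxy in place of hydrogen on an aromatic carbon. Among the measured compounds shown here, that step concerns the same phenyl group, but no measured compound yet carries a methoxy group, so the evidence is thin. On this basis, no shift beyond the scatter is expected in this assay, and no direction is favoured. The expected step is a 1.1-fold lower number from compound 2 to compound 3 (0.04 log units; within the scatter). For compound 3 the estimated value is 45000 nM, with an expected range from 18000 nM to 100000 nM.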

Compound 3, concentration for total growth inhibition: 58900 nM
For compound 3 the middle estimate is 1.3-fold (0.12 log units) below the measured one; the measured number falls inside the stated range.
By their numbers in this assay, from the lowest: compounds 1, 2 and 3 (each within the scatter of the next).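

In this assay, 2,6-dimethoxyphenyl in place of 4-hydroxyphenyl on the carbon with a double bond to nitrogen gives a 1.2-fold higher number from compound 2 to compound 3 (0.08 log units; within the scatter), and the same group in place of phenyl gives a 1.3-fold higher number from compound 1 to compound 3 (0.10 log units; within the scatter). Within the data shown here, this is the first methoxy-bearing group measured at this position, and neither step leaves the scatter, even though the group that enters differs from 4-hydroxyphenyl in its counts of heavy atoms, hydrogen-bond donors and hydrogen-bond acceptors. No measurement is available here that would explain this result.

The compounds shown leave open how an amine or a carboxylic acid on this phenyl ring would read in this assay. They also leave open whether these three groups would stay within the scatter of each other on a core other than the shared one.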